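This account rests on a few compounds, and the source may have more. Where it says the series, first, only, none or still open, it means among the compounds named here.

Measured so far:

Compound 1, `NC(=O)c1c(NC(=O)c2ccccc2Cl)sc2c1CCN(Cc1ccccc1)C2`: 12000 nM
Compound 2, `NC(=O)c1c(NC(=O)c2ccccc2Cl)sc2c1CCN(Cc1ccc([N+](=O)[O-])cc1)C2`: 11400 nM
Compound 3, `NC(=O)c1c(NC(=O)c2ccccc2Cl)sc2c1CCN(C(=S)Nc1ccccc1Br)C2`: 9090 nM

All three share one core and differ only in the group carried by the amine nitrogen in the ring. In a functional assay on HL-60 cells (Homo sapiens) for antiproliferative activity, with a stated time of 24 h (on this read-out higher numbers stand for weaker inhibition and lower numbers for stronger inhibition), compound 3 gives 9090 nM, the lowest of the three numbers, though neither of the other two is separated from it by more than the scatter: a 1.3-fold lower number from compound 1 to compound 3 (0.12 log units; within the scatter), and a 1.3-fold lower number from compound 2 to compound 3 (0.10 log units; within the scatter). The remaining pair is closer still, a 1.1-fold lower number from compound 1 to compound 2 (0.02 log units; within the scatter). On these numbers, then, swapping the group on that nitrogen has so far moved nothing beyond what repeated measurement would show by itself.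

Compound 4, `NC(=O)c1c(NC(=O)c2ccccc2Cl)sc2c1CCN(C(=O)Nc1c(Cl)cccc1Cl)C2`, carries yet another group at that same position. The change from compound 3 is a group of 11 heavy atoms (7 carbon, 1 nitrogen, 1 oxygen, 2 chlorine; one six-membered aromatic ring of carbon only) in place of a group of 10 heavy atoms (7 carbon, 1 nitrogen, 1 sulfur, 1 bromine; one six-membered aromatic ring of carbon only), on an amine nitrogen in a ring. The two steps that bear on it are the earlier swaps at this nitrogen, from compound 1 and from compound 2 to compound 3, each within the scatter. The expected outcome for compound 4 is therefore no step beyond the scatter, a 1.0-fold higher number from compound 3 to compound 4 (0.02 log units; within the scatter). In this assay compound 4 is estimated at 9500 nM, with a range from 4500 nM to 20000 nM.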

Compound 4, half-maximal inhibitory concentration: 17700 nM
Estimate against measurement, compound 4: 1.9-fold (0.27 log units) below, and the stated range covers the measured number.
By their numbers in this assay, from the lowest: compounds 3, 2, 1 and 4 (each within the scatter of the next).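

In this assay the (2,6-dichlorophenyl)carbamoyl group on the amine nitrogen in the ring gives a 1.9-fold higher number from compound 3 to compound 4 (0.29 log units; within the scatter) and a 1.6-fold higher number from compound 2 to compound 4 (0.19 log units; within the scatter) and a 1.5-fold higher number from compound 1 to compound 4 (0.17 log units; within the scatter) as its three steps, so it stands within the scatter of every earlier group. Among these compounds, this widens the flat picture at this position: compared with compound 3, the group now trades sulfur and bromine for oxygen and chlorine, and compared with compound 1 and compound 2, it replaces a benzyl-type group, yet no step among the four compounds goes beyond the scatter. No measurement is available that would explain this result or tie it to any feature of the groups.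

All four groups shown contain a six-membered aromatic ring of carbon only, so it remains open whether the number would stay in the same range with only hydrogen on that nitrogen, with a short alkyl chain such as methyl, or with a benzyl group carrying a carboxylic acid or an amine. The rest of the shared core is also the same in all four compounds, so these results say nothing about changes made elsewhere on it.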